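Swapping Benzyl for Dimethoxyphenyl on a Urea Nitrogen

The source may hold more compounds than are shown below. What is called first, only, known or untested is meant among the compounds shown, and "the series" means these compounds.

Compound 1 `O=C(Nc1ccc(Cl)cc1)Nc1nn(-c2ccccc2)c(=O)c2ccccc12` and compound 2 `O=C(NCc1ccccc1)Nc1nn(-c2ccccc2)c(=O)c2ccccc12` share one core and differ only in the group on an amide-type nitrogen. Among the compounds with values here, in an assay on CHO cells for displacement of a labelled ligand from adenosine receptor A1 (Homo sapiens), tested at 10 uM (a higher number here means more inhibition at the concentration tested (going by the name of the read-out), a lower number less inhibition), compound 1 gives 10% and compound 2 gives 20%; the step of a number 10 percentage points higher from compound 1 to compound 2 (within the scatter) means the two cannot be told apart on the numbers so far. Compound 3 `COc1ccc(NC(=O)Nc2nn(-c3ccccc3)c(=O)c3ccccc23)c(OC)c1` changes the same nitrogen: 2,4-dimethoxyphenyl in place of benzyl on an amide-type nitrogen. Within the data shown here, the only measured step that bears on this change, a number 10 percentage points higher from compound 1 to compound 2 (within the scatter), was small, so no step beyond the scatter is expected. The estimated step is a number 5 percentage points lower from compound 2 to compound 3 (within the scatter). Compound 3 is therefore expected to give 15% in this assay, between 0% and 35%.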

Compound 3, a percentage reported as inhibition, at one concentration (the size of the read-out at that concentration, not a potency): 29%
Compound 3: middle estimate off by 14 percentage points, on the low side, within the range that was stated.
By their numbers in this assay, from the lowest: compounds 1, 2 and 3 (each within the scatter of the next, the first and the last beyond it).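

In this assay this amide-type nitrogen shows its first step beyond the scatter: with 2,4-dimethoxyphenyl in place of 4-chlorophenyl, the result is a number 19 percentage points higher from compound 1 to compound 3 (beyond the scatter) and this step is modest. Set against benzyl, the same group gives a number 9 percentage points higher from compound 2 to compound 3 (within the scatter) so these two groups cannot be told apart. Nothing available explains the difference from 4-chlorophenyl.

Still open, on these data alone, is how this nitrogen would respond to a phenyl ring carrying one methoxy, an amine or a carboxylic acid, or to a longer chain such as phenethyl. A reading at one concentration also leaves potency unknown.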